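This account rests on a few compounds, and the source may have more. Where it says the series, first, only, none or still open, it means among the compounds named here.

Measured so far in a functional assay on COLO 205 cells (Homo sapiens) for inhibition, read by MTT assay, with a stated time of 48 h; a higher number here means a weaker inhibitor, a lower number a stronger inhibitor:
- compound 1 `COc1cc(/C=C/C(=O)c2cc(OC)c(OC)c(OC)c2)ccc1O`: > 100000 nM
- compound 2 `COc1cccc(/C=C/C(=O)c2cc(OC)c(OC)c(OC)c2)c1O`: 13000 nM

In this assay compound 1 reads > 100000 nM, which is a limit of the assay and not a number. Among the measured compounds shown here, compound 2 gives 13000 nM, the only numerical value so far.

Compound 3 `COc1cc(C(=O)/C=C/c2ccc(O)c(O)c2)cc(OC)c1OC` comes from compound 1 by one change, hydrogen in place of methyl on an oxygen on an aromatic ring, that is, methoxy to hydroxy. For the measured compounds named here, no measured pair shows this change, so the expectation is loose. It is anchored on compound 2 at 13000 nM. A result at the limit remains possible for compound 3.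

A moderate move towards stronger inhibition is expected, and the estimated step is an at least 4.0-fold lower number from compound 1 to compound 3 (0.60 log units; beyond the scatter). The estimate for compound 3 is 25000 nM. The expected range for compound 3 runs from 5000 nM to 100000 nM.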

Compound 3, half-maximal inhibitory concentration: 19800 nM
The estimate for compound 3 lay 1.3-fold (0.10 log units) above the measured number; the range from low to high includes it.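

In this assay, among the compounds shown here, hydrogen in place of methyl on an oxygen on an aromatic ring, that is, methoxy to hydroxy, gives an at least 5.0-fold lower number from compound 1 to compound 3 (0.70 log units; beyond the scatter), and this is the first measured pair showing the change. Compound 1 reads > 100000 nM, which is a limit of the assay and not a number. The step therefore fixes only a minimum size, and its full size stays unknown: the limit of > 100000 nM in this assay, at which 1 of the 3 values shown sits.

From the compounds shown here alone, whether the same change on another oxygen of the shared core, or on a different core, gives a step of similar size remains open, as this is a single pair. Going by these compounds, how an ethoxy group or a longer chain ending in an amine would read on this oxygen is also open.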